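The source may report more compounds than this note shows. Statements on the series, on what has been measured and on what is new or still open speak of the compounds shown alone.

For the measured compounds named here, compound 2 `CC(C)(C)C1CCC(N(Cc2ccc(C(=O)NCC(=O)O)cc2)C(=O)Nc2ccc(OC(F)(F)F)cc2)CC1` holds the only plain number in this set: in an in vitro assay on BHK cells for inhibition of Glucagon receptor (Homo sapiens) (a lower number here means a stronger inhibitor, a higher number a weaker inhibitor), compound 2 gives 1700 nM. Compound 1 `CC(C)(C)C1CCC(N(Cc2ccc(C(=O)NCCCC(=O)O)cc2)C(=O)Nc2ccc(OC(F)(F)F)cc2)CC1` shows only a limit of this assay, > 10000 nM, so no number is known for compound 1 (the limit of > 10000 nM in this assay, at which 1 of the 2 values shown sits). The single step shown, an at least 5.8-fold lower number from compound 1 to compound 2 (0.76 log units; beyond the scatter), shortened the acid-bearing chain and gave a stronger binder, and this is all the evidence on how this part of the molecule matters. Compound 3 `CC(C)(CC(=O)O)NC(=O)c1ccc(CN(C(=O)Nc2ccc(OC(F)(F)F)cc2)C2CCC(C(C)(C)C)CC2)cc1` changes the same part: 1-(carboxymethyl)-1-methylethyl in place of carboxymethyl on an amide-type nitrogen. Going by the values given here, the 1-(carboxymethyl)-1-methylethyl group keeps the acid at the same distance from the amide-type nitrogen as in compound 2 but is branched where it meets that nitrogen, a kind of change no measured pair shows. The measured step only tells that this region is sensitive, so a step of modest size in either direction, or none beyond the scatter, is expected. Compound 3 is therefore estimated at 1800 nM, with a range from 500 nM to 6000 nM. That expectation amounts to a 1.1-fold higher number from compound 2 to compound 3 (0.02 log units; within the scatter).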

Compound 3, half-maximal inhibitory concentration: > 10000 nM
Compound 3 gave a limit, no number (the forecaster's own chance of this, stated with the estimate: 12%); at least 5.5-fold (0.74 log units) between middle value and limit.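

With an at least 5.8-fold higher number from compound 2 to compound 3 (0.76 log units; beyond the scatter), the branched 1-(carboxymethyl)-1-methylethyl group proves no better tolerated on the amide-type nitrogen than the longer 3-carboxypropyl group of compound 1. Among these three compounds, the carboxymethyl group of compound 2 is the only one that gives a readable number in this assay, so the earlier loss of binding is not confined to lengthening the chain. Compound 1 and compound 3 both give only a limit of the assay, and the step between them cannot be read: the limit of > 10000 nM in this assay, at which 2 of the 3 values shown sit.

As far as these compounds go, how much binding either of these two groups loses remains unknown. Also open, from the compounds shown here alone, is whether a smaller branch, such as 1-carboxyethyl, would be tolerated on this nitrogen, and whether an amine or an amide could stand in place of the carboxylic acid.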